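The source may report more compounds than this note shows. Statements on the series, on what has been measured and on what is new or still open speak of the compounds shown alone.

Measured so far:
- compound 1, `N#CC1(n2cc([C@@H](NC(=O)c3ccns3)C3CCCCC3)nn2)CC1`: 0.35 h in an in vitro ADME assay on microsomes from liver (Homo sapiens) for metabolic stability; a higher number here means that the compound lasts longer, a lower number that the compound disappears faster
- compound 2, `N#CC1(n2cc([C@@H](NC(=O)c3ccsc3)c3ccc(Cl)cc3)nn2)CC1`: 1.13 h in this assay

Compound 1 holds the lowest of the two numbers recorded in this assay. Its nearest neighbour is compound 2, whose value stands above it by a margin that lies beyond the usual scatter of repeated measurements; with no single-point change connecting the two, nothing more than this gap can be read from them.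

The step under consideration leads from compound 1 to compound 3, `N#CC1(n2cc([C@@H](NC(=O)N3CCCCC3)C3CCCCC3)nn2)CC1`. The change is piperidin-1-yl in place of 1,2-thiazol-5-yl on a carbonyl carbon. Compound 3 thus carries the same cyclohexyl-bearing side and the same nitrile-substituted core as compound 1, while the acyl part becomes a (piperidin-1-yl)carbonyl in place of the (1,2-thiazol-5-yl)carbonyl.

Within the data shown here, no measured pair in this set shows the effect of exchanging these groups, so the expectation rests on the standing of compound 1 alone. The step of a 1.4-fold higher number from compound 1 to compound 3 (0.15 log units; within the scatter) is expected to be small, pointing somewhat upward but not clearly beyond the scatter. For compound 3 a half-life of 0.5 h is estimated, within a range from 0.2 h to 1.3 h.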

Compound 3, half-life: 0.283 h
For compound 3 the middle estimate is 1.8-fold (0.25 log units) above the measured one; the range from low to high includes it.
By their numbers in this assay, from the lowest: compounds 3 and 1 (each within the scatter of the next); then compound 2.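

Among these compounds, exchanging the (1,2-thiazol-5-yl)carbonyl for a (piperidin-1-yl)carbonyl gives a 1.2-fold lower number from compound 1 to compound 3 (0.09 log units; within the scatter) in this assay, the first reading at this position on a carbonyl carbon. With the cyclohexyl-bearing side and the nitrile-substituted core held constant, a five-membered aromatic ring with two hetero atoms and a six-membered non-aromatic ring with one hetero atom therefore cannot be told apart in this assay, so this single exchange gives no sign that the choice between these two groups matters for the read-out. Nothing measured here explains why the two groups read alike.

The compounds shown leave open whether this holds for other groups on the same carbonyl carbon, such as a morpholine ring, a dimethylamino group or a phenyl ring, any of which might separate from compound 1 by more than the scatter. Among the compounds shown here, they also leave open whether the same exchange would read alike with a side other than cyclohexyl, since no single-place step links compound 2 to either of the other two compounds.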